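Benzylamine replacement by ethylpiperazine in a diaryl ether series

This account rests on a few compounds, and the source may have more. Where it says the series, first, only, none or still open, it means among the compounds named here.

Measured compounds:
compound 1, `COc1ccc(CNCc2c(OC)cc(Oc3cccc(Nc4ccccc4)c3)cc2OC)cc1`; in a functional assay on HCT-15 cells (Homo sapiens) for inhibition, read by MTT assay, with a stated time of 72 h (on this read-out higher numbers stand for weaker inhibition and lower numbers for stronger inhibition), compound 1 gives 2650 nM
compound 2, `COc1cc(Oc2cccc(Nc3ccccc3)c2)cc(OC)c1CNCc1ccc(F)cc1`; in this assay compound 2 gives 3640 nM
compound 3, `COc1cc(Oc2cccc(Nc3ccccc3)c2)cc(OC)c1CNCc1ccc(Cl)cc1`; in this assay compound 3 gives 4850 nM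

Compound 2 stands second highest of the three numbers, and its steps to both neighbours lie within the scatter: a 1.4-fold higher number from compound 1 to compound 2 (0.14 log units; within the scatter) and a 1.3-fold higher number from compound 2 to compound 3 (0.12 log units; within the scatter). Compound 4, `CCN1CCN(Cc2c(OC)cc(Oc3cccc(Nc4ccccc4)c3)cc2OC)CC1`, differs from compound 2 as 4-ethylpiperazin-1-yl in place of (4-fluorobenzyl)amino on a saturated chain carbon bound to an aromatic carbon. The measured steps, a 1.8-fold higher number from compound 1 to compound 3 (0.26 log units; within the scatter) included, each exchange one group on the benzyl ring and all stay within the scatter; none alters the amine itself, so they give no direct read on this larger change. With no basis for a direction, the expected outcome is a 1.1-fold higher number from compound 2 to compound 4 (0.04 log units; within the scatter), carrying wide uncertainty. For compound 4 the estimate in this assay is 4000 nM, range 1200 nM to 15000 nM.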

Compound 4, half-maximal inhibitory concentration: 5090 nM
The estimate for compound 4 lay 1.3-fold (0.10 log units) below the measured number; low and high end bracket the measured number.
By their numbers in this assay, from the lowest: compounds 1, 2, 3 and 4 (each within the scatter of the next).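

In this assay the amine itself now changes, and the steps of a 1.4-fold higher number from compound 2 to compound 4 (0.15 log units; within the scatter) and a 1.0-fold higher number from compound 3 to compound 4 (0.02 log units; within the scatter) and a 1.9-fold higher number from compound 1 to compound 4 (0.28 log units; within the scatter) all stay within the scatter. At this saturated chain carbon bound to an aromatic carbon, 4-ethylpiperazin-1-yl, which carries no aromatic ring and no hydrogen-bond donor, therefore gives a number that cannot be told apart from those of the benzylamino compounds. No supporting data bear on this result. Going by these compounds, whether a morpholine, a dimethylamino group or a piperazine with a longer chain on nitrogen would move the number beyond the scatter stays open.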